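Cytotoxicity notes: removing the nitro from compound 1

A few compounds are considered here, and "the series" means these few. Any claim that something is new, unique, unknown or untested is made for them only; others in the source may bear on it.

Measured compounds:
Compound 1, `Cc1ccc(NC(=O)CSc2snnc2-c2ccc(Br)cc2Br)c([N+](=O)[O-])c1`, in an ADME assay on MT4 cells (Homo sapiens) for cytotoxicity, read by MTT assay, with a stated time of 5 days (on this read-out lower numbers stand for higher toxicity in this test and higher numbers for lower toxicity in this test), reaches only a limit of > 229000 nM.
Compound 2, `O=C(CSc1snnc1-c1ccc(Br)cc1Br)Nc1ccccc1F`, in this assay reaches only a limit of >= 27800 nM.
Compound 3, `O=C(CSc1snnc1-c1ccc(Br)cc1Br)Nc1ccccc1Br`, in this assay reaches only a limit of > 221000 nM.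

Compound 1 stands at a limit, as do the other two values, shown by the limit of > 229000 nM in this assay, at which 1 of the 3 values shown sits, the limit of > 221000 nM in this assay, at which 1 of the 3 values shown sits, and (the limit of >= 27800 nM in this assay, at which 1 of the 3 values shown sits). Among the measured compounds shown here, the one measured step, a step that the two limits leave unreadable from compound 2 to compound 3, is bromo in place of fluoro on an aromatic carbon, and its size cannot be read from two limits. The change to compound 4, `Cc1ccc(NC(=O)CSc2snnc2-c2ccc(Br)cc2Br)cc1`, is hydrogen in place of nitro on an aromatic carbon. For the measured compounds named here, no measured step touches the nitro group, so no shift beyond the scatter is expected in this assay. Compound 4 is therefore expected near the limit of compound 1, estimated at 250000 nM (range 100000 nM to 600000 nM), a step that the limit leaves unreadable from compound 1 to compound 4.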

Compound 4, half-maximal cytotoxic concentration: 24000 nM
The estimate for compound 4 lay 10-fold (1.02 log units) above the measured number, and the stated range ends above it.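

In this assay, among the compounds shown here, compound 4 carries the only value of the series that is not a limit, so this position on the ring, ortho to a large group, now has a readable floor: hydrogen in place of nitro gives an at least 9.5-fold lower number from compound 1 to compound 4 (0.97 log units; beyond the scatter). Against the 2-bromophenyl amide, the 4-methylphenyl amide gives an at least 9.2-fold lower number from compound 3 to compound 4 (0.96 log units; beyond the scatter). Against the 2-fluorophenyl amide, it gives an at least 1.1-fold lower number from compound 2 to compound 4 (0.06 log units; that floor lies within the scatter), so no firm change can be read there.

On these data alone, the full size of the nitro step stays open, because compound 1 stands at a limit: the limit of > 229000 nM in this assay, at which 1 of the 4 values shown sits. As far as these compounds go, whether an amine or a carboxylic acid at this position would keep the number of compound 1 or fall towards that of compound 4 also stays open.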